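The source may report more compounds than this note shows. Statements on the series, on what has been measured and on what is new or still open speak of the compounds shown alone.

In a functional assay, with a stated time of 10 min (on this read-out lower numbers stand for stronger inhibition and higher numbers for weaker inhibition), compound 1 (`CCOc1cc(OC)ccc1C(C)=O`) gives 35300000 nM, and compound 2 (`CCCCCCCCOc1cc(OC)ccc1C(C)=O`) gives 69400000 nM. Within the data shown here, these are the only two measurements so far, and they lie within the scatter of each other, so compound 2 stands level with compound 1 on these numbers.

Compound 3 (`CCCCCCCCCCCCCCCCOc1cc(OC)ccc1C(C)=O`) keeps the shared core and extends the chain of compound 2 further: octyl in place of hydrogen on a saturated chain carbon, eight bonds along the chain from an oxygen on an aromatic ring. Among the measured compounds shown here, the only measured step that bears on this change is the one other extension of the same chain, with hexyl in place of hydrogen: a 2.0-fold higher number from compound 1 to compound 2 (0.29 log units; within the scatter). For the measured compounds named here, that step stayed within the scatter, but it is a single step, and no measured compound carries a chain as long as the one in compound 3. A large move is therefore not expected, and any drift would most plausibly continue toward higher numbers.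

The expected change is an estimated 1.2-fold higher number from compound 2 to compound 3 (0.06 log units; within the scatter), which would not go beyond the scatter. In this assay the estimated value for compound 3 is 80000000 nM, with an expected range of 30000000 nM to 250000000 nM.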

Compound 3, half-maximal inhibitory concentration: 61500000 nM
Beside the measured number, compound 3's estimate is 1.3-fold (0.11 log units) above it; the range from low to high includes it.
By their numbers in this assay, from the lowest: compounds 1, 3 and 2 (each within the scatter of the next).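

In this assay, the new step reads a 1.1-fold lower number from compound 2 to compound 3 (0.05 log units; within the scatter), so octyl in place of hydrogen at this position, on a saturated chain carbon eight bonds along the chain from an oxygen on an aromatic ring, gives no separation that can be read. The earlier step, a 2.0-fold higher number from compound 1 to compound 2 (0.29 log units; within the scatter), could not show on its own whether a drift toward higher numbers would continue as the chain grew, and this second step shows no such drift, since compound 1, compound 3 and compound 2, taken in order of their numbers, each stand within the scatter of the next. No measured finding is at hand to account for this level reading.

The compounds shown are all plain saturated chains on that oxygen, so it remains open whether a chain ending in an amine or a carboxylic acid, or a benzyl group in its place, would stand level with them or move clear of the scatter. They also leave open whether the same level reading would hold if the carbonyl of the shared core gave way to an amide.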